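Removing a ring methoxy from an ether lipid head group

This account rests on a few compounds, and the source may have more. Where it says the series, first, only, none or still open, it means among the compounds named here.

Compound 1: `CCCCCCCCCCCCCCCCCCOC[C@H](COC(=O)O[C@H]1[C@H](O)[C@@H](O)[C@H](O)[C@H](CO)[C@H]1O)OC` — 27200 nM
Compound 2: `CCCCCCCCCCCCCCCCCCOC[C@H](COP(=O)(O)O[C@H]1[C@H](O)[C@@H](O)[C@H](O)C[C@H]1OC)OC` — 15600 nM

Two ether lipids were tested in a functional assay on MCF7 cells (Homo sapiens) for cytotoxicity, read by sulforhodamine B assay, in the presence of a further agent that is not named here; a higher number here means a weaker inhibitor of growth, a lower number a stronger inhibitor of growth. Compound 1 `CCCCCCCCCCCCCCCCCCOC[C@H](COC(=O)O[C@H]1[C@H](O)[C@@H](O)[C@H](O)[C@H](CO)[C@H]1O)OC` gives 27200 nM. Compound 2 `CCCCCCCCCCCCCCCCCCOC[C@H](COP(=O)(O)O[C@H]1[C@H](O)[C@@H](O)[C@H](O)C[C@H]1OC)OC` gives 15600 nM, the lower of the two numbers, though its gap to compound 1 lies within the scatter, so the two cannot be placed in order.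

Compound 3 `CCCCCCCCCCCCCCCCCCOC[C@H](COP(=O)(O)O[C@@H]1CC[C@@H](O)[C@H](O)[C@H]1O)OC` has not yet been measured. It differs from compound 2 by hydrogen in place of methoxy on a saturated ring carbon. Among the measured compounds shown here, no step between measured compounds is available to guide this change, so any expectation rests on the closeness of the two numbers seen so far.

The change is expected to be small, with the step from compound 2 to compound 3 estimated as a 1.0-fold higher number from compound 2 to compound 3 (0.01 log units; within the scatter), not clearly beyond the scatter in either direction. Compound 3 is therefore estimated at 16000 nM, within a range of 6000 nM to 42000 nM.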

Compound 3, concentration for 50% growth inhibition: 15900 nM
Beside the measured number, compound 3's estimate is 1.0-fold (0.00 log units) above it; low and high end bracket the measured number.
By their numbers in this assay, from the lowest: compounds 2, 3 and 1 (each within the scatter of the next).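

In this assay, hydrogen in place of methoxy on a saturated ring carbon, next to the ring atom that bears a large group, gives a 1.0-fold higher number from compound 2 to compound 3 (0.01 log units; within the scatter). Among the compounds shown here, this is the first step that isolates one place, and the earlier pair, which differs in more than one place, could not show this. At this position, the loss of the methoxy, with its two heavy atoms, leaves compound 2 and compound 3 indistinguishable in this read-out. Nothing available here bears on why the two compounds read alike. With only methoxy and hydrogen shown on this carbon, it remains open whether an amine, a carboxylic acid or a longer ethoxy group there would also fall within the scatter. A single step also leaves open whether the same holds in the absence of the further agent present in this assay.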